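Swapping the amide substituent on a pyrazole carboxamide core

A few compounds are considered here, and "the series" means these few. Any claim that something is new, unique, unknown or untested is made for them only; others in the source may bear on it.

This account follows two compounds that share a dimethoxybenzamide-pyrazole core and differ only in the group on the terminal amide-type nitrogen. Compound 1 `COc1cccc(OC)c1C(=O)Nc1c[nH]nc1C(=O)NC1CCN(Cc2ccccc2)C1` carries a benzyl-substituted pyrrolidine, and in an ADME assay on MRC5 cells (Homo sapiens) for inhibition, with a stated time of 72 h (on this read-out lower numbers stand for an effect already at smaller amounts and higher numbers for an effect only at larger amounts of compound), compound 1 gives 38000 nM. Compound 2 `COc1cccc(OC)c1C(=O)Nc1c[nH]nc1C(=O)N[C@H]1CC[C@H](O)CC1` carries a 4-hydroxycyclohexyl group, and in this assay compound 2 gives 34000 nM. These two numbers lie within the usual scatter of each other, so neither compound can be said to differ from the other on this read-out.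

Compound 3 `COc1cccc(OC)c1C(=O)Nc1c[nH]nc1C(=O)NCc1ccccn1` has not yet been measured. It differs from compound 2 in one place: (pyridin-2-yl)methyl in place of 4-hydroxycyclohexyl on an amide-type nitrogen. Going by the values given here, no measured pair shows the effect of this particular exchange, so the expectation rests on the observation that the two measured compounds, with quite different groups on the same amide-type nitrogen, sit at about the same level.

The expected step from compound 2 to compound 3 in this assay is a 1.0-fold higher number from compound 2 to compound 3 (0.01 log units; within the scatter), that is, nothing beyond the scatter. Compound 3 is therefore estimated at 35000 nM, with a likely range from 15000 nM to 80000 nM.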

Compound 3, half-maximal effective concentration: > 50000 nM
Compound 3: only a limit was reported; the forecaster's own chance of this, stated with the estimate: 20%; at least 1.4-fold (0.15 log units) between middle value and limit.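

The exchange of 4-hydroxycyclohexyl for (pyridin-2-yl)methyl on the amide-type nitrogen gives, in this assay, an at least 1.4-fold higher number from compound 2 to compound 3 (0.16 log units; that floor lies within the scatter). Unlike the two earlier compounds, which sit within the scatter of each other, this new group brings an aromatic ring to the position, has 0 hydrogen-bond donors and no defined stereocentres, and still yields no lower number on this read-out. The entry for compound 3 is a limit and not a number, so this position gains a floor rather than a measured level: the limit of > 50000 nM in this assay, at which 1 of the 3 values shown sits.

The compounds shown leave open whether the true value of compound 3 stands beyond the scatter from compound 2, so the size of this step, and any part played in it by the hydroxyl group or the pyridine nitrogen, cannot be read. They also leave open whether any other group on this amide-type nitrogen, such as a carboxylic acid, an open-chain amine or a longer chain, would shift the number in either direction.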